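A Methoxy-to-Oxazole Step and Its Expected Cytotoxicity

The compounds below may be only part of what the source reports. "The series", "measured", "known", "first", "only" and "open" are said of these compounds alone.

Compound 1 `COc1cccc(C(=O)N2CCCC(C(=O)Nc3ccc(Cl)cc3)C2)c1` was tested in an ADME assay on PC-3 cells (Homo sapiens) for cytotoxicity, read by WST assay, tested at 100 uM (on this read-out lower numbers stand for less inhibition and higher numbers for more inhibition at the one concentration tested (going by the name of the read-out)), and compound 1 gives 0% there. Two related compounds have been measured in the same way. Compound 2 `O=C(Nc1ccc(Cl)nc1)C1CCCN(C(=O)c2cc(C(F)(F)F)cc(C(F)(F)F)c2)C1` gives 25% in this assay. Compound 3 `O=C(Nc1cccc(S(=O)(=O)N2CCCC2)c1)C1CCCN(C(=O)c2cc(C(F)(F)F)cc(C(F)(F)F)c2)C1` gives 0% in this assay. Compound 1 and compound 3 are level at the digits reported, within the scatter, and together they are the lowest of the three; compound 2 is the only one of the three that stands beyond the scatter above compound 1.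

Compound 4 `O=C(Nc1ccc(Cl)cc1)C1CCCN(C(=O)c2cccc(-c3cnco3)c2)C1` has not yet been measured in this assay. It differs from compound 1 in one place: 1,3-oxazol-5-yl in place of methoxy on an aromatic carbon

Going by the values given here, none of the measured compounds differ from one another in a single place, so no measured pair shows how a single change shifts this read-out. Two of the three measured compounds, compound 1 and compound 3, sit at the floor of the read-out, and the change to compound 4 leaves the rest of the molecule as it is in compound 1. Compound 4 is therefore expected to give 5% in this assay, with a range from 0% to 20%. The step of a number 5 percentage points higher from compound 1 to compound 4 (within the scatter) is expected to stay within the scatter, with no clear direction.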

Compound 4, a percentage reported as inhibition, at one concentration (the size of the read-out at that concentration, not a potency): 0%
Estimate against measurement, compound 4: 5 percentage points above, within the range that was stated.
By their numbers in this assay, from the lowest: compounds 1, 3 and 4 (each within the scatter of the next); then compound 2.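

Going by these compounds alone, this is the first single-place comparison, and in this assay the replacement of methoxy by 1,3-oxazol-5-yl gives no change at the digits printed from compound 1 to compound 4 (within the scatter) and nothing beyond it. On this aromatic carbon, meta to a large group, a substituent with a five-membered aromatic ring and more heavy atoms therefore leaves the cytotoxicity read-out where the smaller, ring-free methoxy left it, with compound 4 at 0% in the same assay. Both members of the pair sit at the floor of the read-out, so the step can show that this change brought no rise but could not have shown a fall, and no measurement is at hand that would explain the flat result.

The compounds shown leave open whether any other group on this carbon, such as an amine, a carboxylic acid or a longer alkyl chain, would lift the number off the floor. They also leave open whether the same exchange of methoxy for 1,3-oxazol-5-yl would stay as silent in a compound that starts above the floor.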